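Dropping a Sulfanyl Arm: What Compound 4 Might Show

A few compounds are considered here, and "the series" means these few. Any claim that something is new, unique, unknown or untested is made for them only; others in the source may bear on it.

Three compounds share one core and differ only in the groups hung on it. Compound 1, `CCc1cc(Nc2ccc(C(=O)/C=C/c3cccc(Br)n3)cc2)n2nc(SCc3ccccc3)nc2n1`, compound 2, `Cc1cc(Nc2ccc(C(=O)/C=C/c3cccc(Br)n3)cc2)n2nc(SCc3ccc(Br)cc3)nc2n1`, and compound 3, `C#CCSc1nc2nc(-c3ccccc3)cc(Nc3ccc(C(=O)/C=C/c4cccc(Br)n4)cc3)n2n1`, were all tested in a functional assay on MGC-803 cells (Homo sapiens) for inhibition, read by sulforhodamine B assay, with a stated time of 72 h, tested at 10 uM; a lower number here means less inhibition, a higher number more inhibition at the concentration tested (going by the name of the read-out). Compound 1 gives 63%, compound 2 gives 96.3%, and compound 3 gives 56.3%. Compound 2 thus stands highest of the three, above compound 1 and compound 3 by margins that exceed the usual scatter of the measurement.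

The step under consideration leads from compound 2 to compound 4, `Cc1cc(Nc2ccc(C(=O)/C=C/c3cccc(Br)n3)cc2)n2ncnc2n1`, which has not yet been measured. The change is hydrogen in place of (4-bromobenzyl)sulfanyl on an aromatic carbon. In words, hydrogen takes the place of (4-bromobenzyl)sulfanyl on an aromatic carbon, so compound 4 lacks any sulfanyl group at that position.

Among the measured compounds, those that carry different sulfanyl substituents give clearly different numbers, so removing the group entirely is unlikely to be neutral. Compound 4 is therefore expected to fall below compound 2, with an estimated step of a number 41.3 percentage points lower from compound 2 to compound 4 (beyond the scatter) in this assay. Compound 4 is expected to give about 55%, within a range from 20% to 88%.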

Compound 4, a percentage reported as inhibition, at one concentration (the size of the read-out at that concentration, not a potency): 58.4%
For compound 4 the middle estimate is 3.4 percentage points below the measured one; low and high end bracket the measured number.
By their numbers in this assay, from the lowest: compounds 3, 4 and 1 (each within the scatter of the next); then compound 2.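

In this assay, going by these compounds alone, the only step that changes a single place is the replacement of (4-bromobenzyl)sulfanyl by hydrogen, and it gives a number 37.9 percentage points lower from compound 2 to compound 4 (beyond the scatter); compounds 1, 2 and 3 differ from one another in more than one place, so they could not show what this group contributes on its own. Even with the whole arm gone, compound 4 reads 58.4%, so inhibition at the concentration tested does not depend on having the (4-bromobenzyl)sulfanyl group on this aromatic carbon, although its presence in compound 2 goes with a clearly higher number. Nothing available here gives a reason for the size of this step.

The compounds shown do not tell how much of the step belongs to the sulfur, the six-membered aromatic ring or the bromine, since compound 1, which carries a benzylsulfanyl arm without bromine, also has ethyl in place of methyl elsewhere on the core. As far as these compounds go, it also remains open whether a smaller group on this carbon, such as methylsulfanyl or an amine, would give a number nearer that of compound 2 or that of compound 4.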